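Replacing the Amide Aryl Group with Cyclopropyl: Expected Clearance

The compounds below may be only part of what the source reports. "The series", "measured", "known", "first", "only" and "open" are said of these compounds alone.

Measured so far in an in vitro ADME assay on microsomes from liver (Homo sapiens) for pharmacokinetics, read by LC-MS, with a stated time of 10 min, tested at 1 uM; on this read-out higher numbers stand for fast clearance and lower numbers for slow clearance:
- Compound 1, `CN1C[C@H](C(=O)Nc2ccc(C3CC3)cc2)[C@@H](c2ccc(/C=C/C(=O)Nc3ccccc3N)cc2)C1`, gives 12 mL/min/kg.
- Compound 2, `CN1C[C@H](C(=O)Nc2ccccc2F)[C@@H](c2ccc(/C=C/C(=O)Nc3ccccc3N)cc2)C1`, gives 10 mL/min/kg.
- Compound 3, `CN1C[C@H](C(=O)Nc2ccc(Cl)c(Cl)c2)[C@@H](c2ccc(/C=C/C(=O)Nc3ccccc3N)cc2)C1`, gives 14 mL/min/kg.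

The three compounds share one core and differ only in the group on the amide-type nitrogen. Compound 3 gives the largest of the three numbers, but the gaps to its neighbours are small: a 1.2-fold higher number from compound 1 to compound 3 (0.07 log units; within the scatter), and a 1.4-fold higher number from compound 2 to compound 3 (0.15 log units; within the scatter). Neither gap exceeds the usual scatter, so the three numbers are best read as one level.

Compound 4, `CN1C[C@H](C(=O)NC2CC2)[C@@H](c2ccc(/C=C/C(=O)Nc3ccccc3N)cc2)C1`, is not yet measured. The change from compound 3 is cyclopropyl in place of 3,4-dichlorophenyl on an amide-type nitrogen. For the measured compounds named here, none of the measured steps tests this kind of change: each swaps one substituted phenyl for another, and all three are within the scatter, including a 1.2-fold lower number from compound 1 to compound 2 (0.08 log units; within the scatter). Going by the values given here, there is no measured step that exchanges an aromatic group for a small saturated ring, so the direction of any shift in this assay cannot be read from the data. On the evidence of three flat steps, compound 4 is expected to show a 1.3-fold lower number from compound 3 to compound 4 (0.10 log units; within the scatter). Compound 4 is therefore estimated at 11 mL/min/kg, with a range from 5 mL/min/kg to 22 mL/min/kg reflecting the untested nature of this change.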

Compound 4, clearance: 10 mL/min/kg
The estimate for compound 4 lay 1.1-fold (0.04 log units) above the measured number, within the range that was stated.
By their numbers in this assay, from the lowest: compounds 2, 4, 1 and 3 (each within the scatter of the next).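

Compound 4 is the first compound shown with no aromatic ring on the amide-type nitrogen: cyclopropyl, with 3 heavy atoms, stands where 3,4-dichlorophenyl has 8. Even so, in this assay this swap keeps clearance at the same level as each phenyl-bearing compound (a 1.4-fold lower number from compound 3 to compound 4 (0.15 log units; within the scatter); a 1.2-fold lower number from compound 1 to compound 4 (0.08 log units; within the scatter); no change at the digits printed from compound 2 to compound 4 (within the scatter)), so across these four compounds, neither the aromatic ring nor the larger group on this nitrogen separates the numbers beyond the scatter. Nothing measured here explains why clearance stays level across such different groups.

On these data alone, it remains open whether the same level would hold with a group of another kind on this nitrogen, such as a longer chain, an amine or a carboxylic acid. All four compounds also share the rest of their structure, so they cannot show whether clearance in this assay would respond to a change elsewhere in the molecule.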